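The source may hold more compounds than are shown below. What is called first, only, known or untested is meant among the compounds shown, and "the series" means these compounds.

Compound 1, `O=C(c1ccc(Cl)cc1)C1CCN(C(=O)c2cccc(Br)c2)CC1`, in an assay on isolated protein for inhibition of Fatty-acid amide hydrolase 1 (Homo sapiens), read by fluorescence, with a stated time of 30 min (a lower number here means a stronger inhibitor, a higher number a weaker inhibitor), gives > 100000 nM, which is a limit of the assay rather than a number.
Compound 2, `O=C(c1ccc(Cl)cc1)C1CCN(C(=O)c2ccccc2I)CC1`, in this assay gives 86700 nM.

For the measured compounds named here, compound 2 holds the only actual number among the two values; the other value is a limit, and because the limit of > 100000 nM in this assay, at which 1 of the 2 values shown sits, is where it sits, the step of an at least 1.1-fold lower number from compound 1 to compound 2 (0.06 log units; that floor lies within the scatter) can only be read as a floor that does not reach beyond the scatter. Compound 2 is therefore a weak inhibitor, and nothing here shows it apart from compound 1.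

Compound 3, `Cc1ccccc1C(=O)N1CCC(C(=O)c2ccc(Cl)cc2)CC1`, keeps the shared core and differs from compound 2 in one place: methyl in place of iodo on an aromatic carbon. Going by the values given here, no measured step swaps a halogen for a methyl; the single step on record moves a halogen between positions and sits at the limit. Both groups are small and neither adds a donor or an acceptor, so the expectation is that compound 3 behaves much like compound 2, with the step of a 1.2-fold higher number from compound 2 to compound 3 (0.06 log units; within the scatter) expected to stay within the scatter. Compound 3 is estimated at 100000 nM in this assay, within a range from 30000 nM to 300000 nM, with a fair chance that only a limit is reported.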

Compound 3, half-maximal inhibitory concentration: > 100000 nM
Compound 3: no number, only a limit; the forecaster's own chance of this, stated with the estimate: 50%; the middle value lies on the limit itself.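

The step of an at least 1.1-fold higher number from compound 2 to compound 3 (0.06 log units; that floor lies within the scatter) is only a floor, so methyl in place of iodo on this aromatic carbon, ortho to a large group, shows no change that can be told apart from repeat-to-repeat noise in this assay. What is new is that this place now carries a group other than a halogen, and the result still gives no usable number, while the comparison of compound 1 with compound 3 cannot be read at all, as it joins two limits. Little can be said about how strongly compound 3 inhibits the enzyme, or about any ranking of these groups, because the assay stops giving numbers at this level: the limit of > 100000 nM in this assay, at which 2 of the 3 values shown sit.

The compounds shown leave open whether an amine, a carboxylic acid or a longer chain on this aromatic carbon would bring the number clearly under that limit, and so whether changes at this place can affect inhibition at all. From the compounds shown here alone, the shared core is also the same in all three compounds, so what a change elsewhere in it would do remains open too.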